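This account rests on a few compounds, and the source may have more. Where it says the series, first, only, none or still open, it means among the compounds named here.

Measured so far:

Compound 1 `CCCCCCCCCCn1cc(-c2nc3ccccc3cc2CCCCC)nn1` gives 18.2 ug/mL in a functional assay on U-937 cells (Homo sapiens) for cytotoxicity, read by MTT assay, with a stated time of 24 h; a lower number here means a stronger inhibitor, a higher number a weaker inhibitor.
Compound 2 `Cc1cc2ccccc2nc1-c1cn(-c2ccc(F)cc2)nn1` gives 65.6 ug/mL in this assay.
Compound 3 `CCc1cc2ccccc2nc1-c1cn(CCC(F)(F)C(F)(F)C(F)(F)C(F)(F)C(F)(F)C(F)(F)C(F)(F)C(F)(F)F)nn1` gives 55.9 ug/mL in this assay.

Compound 2 has the highest of the three numbers. Compound 3 sits close by, and the two lie within the scatter of each other, so no order between them can be read. Compound 1 stands apart, with a number low enough to lie beyond the scatter from compound 2.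

The step from compound 2 to the still unmeasured compound 4 `CCCCCc1cc2ccccc2nc1-c1cn(-c2ccc(F)cc2)nn1` is small on paper: butyl in place of hydrogen on a saturated chain carbon bound to an aromatic carbon. Cut one bond further out, the same difference reads methyl to pentyl. Going by the values given here, no measured pair here differs in only this way, so no direct precedent exists. Compound 1, which also carries a pentyl on its core, gives 18.2 ug/mL, but it differs from compound 4 elsewhere as well, so it can only hint at the direction.

For compound 4 a move toward a lower number is expected, with the step of a 1.7-fold lower number from compound 2 to compound 4 (0.24 log units; within the scatter) probably not clearly beyond the scatter. Compound 4 is estimated at 38 ug/mL, in a range from 16 ug/mL to 85 ug/mL.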

Compound 4, half-maximal inhibitory concentration: 67.5 ug/mL
For compound 4 the middle estimate is 1.8-fold (0.25 log units) below the measured one; measured number inside the range.
By their numbers in this assay, from the lowest: compound 1; then compounds 3, 2 and 4 (each within the scatter of the next).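

In this assay, the step of a 1.0-fold higher number from compound 2 to compound 4 (0.01 log units; within the scatter) shows that lengthening methyl to pentyl on this saturated chain carbon makes no readable difference while 4-fluorophenyl sits on the aromatic nitrogen. Compound 4 also forms a clean pair with compound 1, since both carry the pentyl and differ only in the group on that nitrogen, and the step of a 3.7-fold higher number from compound 1 to compound 4 (0.57 log units; beyond the scatter) is modest but beyond the scatter, so the lower number of compound 1 goes with decyl at the nitrogen, not with the pentyl alone. Nothing at hand explains either step.

The compounds shown leave open whether methyl and pentyl would also read alike with decyl on the nitrogen. They also leave open how an amine or a carboxylic acid at the end of the chain would read.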